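Aniline nitrogen methylation and a cyclopropyl amide swap

This account rests on a few compounds, and the source may have more. Where it says the series, first, only, none or still open, it means among the compounds named here.

The measured compounds in an assay on isolated protein for binding affinity to melatonin receptor type 1B (Homo sapiens) (a lower number here means a stronger inhibitor, a higher number a weaker inhibitor), are:
compound 1, `COc1cccc(Nc2ccc(NC(=O)C(C)C)cc2)c1`, giving 84 nM;
compound 2, `COc1cccc(Nc2ccc(NC(=O)C3CC3)cc2)c1`, giving 64 nM;
compound 3, `COc1cccc(N(C)c2ccc(NC(=O)C(C)C)cc2)c1`, giving 5.5 nM.

Compound 4, `COc1cccc(N(C)c2ccc(NC(=O)C3CC3)cc2)c1`, has not yet been measured in this assay. It differs from compound 3 by one change:

cyclopropyl in place of isopropyl on a carbonyl carbon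

The same change has already been made once, from compound 1 to compound 2:

cyclopropyl in place of isopropyl on a carbonyl carbon

There it gave a 1.3-fold lower number from compound 1 to compound 2 (0.12 log units; within the scatter). The two cores on which the change is made are themselves different:

methyl in place of hydrogen on a nitrogen on an aromatic ring

That difference alone gave a 15-fold lower number from compound 1 to compound 3 (1.18 log units; beyond the scatter), and compound 3 therefore stands well apart from compound 1 and compound 2 in this assay. The place of the cyclopropyl swap is the same in both pairs.

Because the earlier swap gave a 1.3-fold lower number from compound 1 to compound 2 (0.12 log units; within the scatter), the account expects a similar small step from compound 3 to compound 4, estimated as a 1.2-fold lower number from compound 3 to compound 4 (0.09 log units; within the scatter). Compound 4 is accordingly estimated to give about 4.5 nM in this assay, most likely within 2 nM to 11 nM.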

Compound 4, inhibition constant: 4.8 nM
Compound 4: the middle estimate sits 1.1-fold (0.03 log units) below what was measured; low and high end bracket the measured number.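

In this assay, the cyclopropyl swap on the core carrying the nitrogen methyl gives a 1.1-fold lower number from compound 3 to compound 4 (0.06 log units; within the scatter), and it carries over from the other core without a change in size: the same change on two cores in this assay, a 1.3-fold lower number (0.12 log units; within the scatter) from compound 1 to compound 2 and a 1.1-fold lower number (0.06 log units; within the scatter) from compound 3 to compound 4, 1.1-fold (0.06 log units) apart, within the scatter of two such steps. The methyl on the nitrogen, taken on the cyclopropyl amide, gives a 13-fold lower number from compound 2 to compound 4 (1.12 log units; beyond the scatter), and this large step also holds from one core to the other: the same change on two cores in this assay, a 15-fold lower number (1.18 log units; beyond the scatter) from compound 1 to compound 3 and a 13-fold lower number (1.12 log units; beyond the scatter) from compound 2 to compound 4, 1.1-fold (0.06 log units) apart, within the scatter of two such steps. Across these four compounds the two changes therefore act independently of each other, but this does not show that cyclopropyl and isopropyl differ in this assay, as both swaps lie within the scatter, and two pairs cannot show that the same would hold for other groups or cores.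

The compounds shown leave open whether an ethyl group on the nitrogen would keep the large step seen with methyl. They also leave open whether a longer chain or a phenyl ring on the carbonyl carbon would behave as isopropyl and cyclopropyl do.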